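The Same Methyl Group Added a Second Time

This account rests on a few compounds, and the source may have more. Where it says the series, first, only, none or still open, it means among the compounds named here.

Compound 1 `O=C(NNC(=S)Nc1csc(-c2ccccc2)c1)c1ccc(O)cc1` and compound 2 `Cc1ccc(-c2cc(NC(=S)NNC(=O)c3ccc(O)cc3)cs2)cc1` share one core, and compound 2 carries methyl in place of hydrogen on an aromatic carbon. In a functional assay on SK-MEL-28 cells (Homo sapiens) for inhibition, read by colorimetric assay and MTT assay, with a stated time of 72 h (a higher number here means a weaker inhibitor, a lower number a stronger inhibitor), compound 1 gives 71000 nM, and compound 2 gives 46000 nM. The resulting step of a 1.5-fold lower number from compound 1 to compound 2 (0.19 log units; within the scatter) is small, so the two numbers cannot be told apart with confidence.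

Compound 3 `COc1cc(OC)cc(C(=O)NNC(=S)Nc2csc(-c3ccccc3)c2)c1` is built on a different core; the difference between the two cores is not broken down here. In this assay compound 3 gives 37000 nM, a number that lies close to those of compound 1 and compound 2, so all three compounds sit within the usual scatter of one another.

Compound 4 `COc1cc(OC)cc(C(=O)NNC(=S)Nc2csc(-c3ccc(C)cc3)c2)c1` has not yet been measured. Among the measured compounds shown here, it differs from compound 3 by methyl in place of hydrogen on an aromatic carbon, which is the same change as the one from compound 1 to compound 2, made at the same place. For the measured compounds named here, the only guide to what this change does is the measured step of a 1.5-fold lower number from compound 1 to compound 2 (0.19 log units; within the scatter), which barely moved the number. For compound 4 a similarly small step a 1.4-fold lower number from compound 3 to compound 4 (0.14 log units; within the scatter) is therefore expected in this assay. Compound 4 is estimated to give 27000 nM, with a likely range from 13000 nM to 60000 nM, resting on a single earlier example of this change and so held loosely.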

Compound 4, half-maximal inhibitory concentration: 38000 nM
Compound 4: the middle estimate sits 1.4-fold (0.15 log units) below what was measured; the range from low to high includes it.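

On the core of compound 3, the change from phenyl to 4-methylphenyl gives a 1.0-fold higher number from compound 3 to compound 4 (0.01 log units; within the scatter) in this assay, so the number with the methyl group cannot be told apart from the number without it. Set beside the earlier example, the two steps also cannot be told apart, which means that the two cores show no measurable difference in how they respond to this change: the same change on two cores in this assay, a 1.5-fold lower number (0.19 log units; within the scatter) from compound 1 to compound 2 and a 1.0-fold higher number (0.01 log units; within the scatter) from compound 3 to compound 4, 1.6-fold (0.20 log units) apart, within the scatter of two such steps

Within these two pairs, then, the methyl group carries over from one core to the other as a step too small to read, but this does not prove that it does nothing or that the two cores respond identically, as steps this small could still hide a slight real effect or a slight difference between the cores.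

The compounds shown leave open whether a different group at the same place on the phenyl ring, such as a chlorine atom, a methoxy group or a longer chain like ethyl, would give a step beyond the scatter. As far as these compounds go, it also remains open whether an amine or a carboxylic acid at that place would do so, and whether the methyl step would hold on any further core.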